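Chlorinated pyrrole dienoate and trienoate esters in this assay

This account rests on a few compounds, and the source may have more. Where it says the series, first, only, none or still open, it means among the compounds named here.

Measured compounds:
compound 1 `CCOC(=O)/C=C/C=C/c1ccc[nH]1`: > 10000 nM
compound 2 `CCOC(=O)/C=C/C=C/C=C/c1ccc[nH]1`: 3670 nM
compound 3 `CCOC(=O)/C=C/C=C/c1[nH]ccc1Cl`: > 10000 nM

Among the measured compounds shown here, in a functional assay on CCRF-CEM cells (Homo sapiens) for cytotoxicity, with a stated time of 72 h (a lower number here means a stronger inhibitor, a higher number a weaker inhibitor), compound 2 gives 3670 nM, the only number in the set. For compound 1 the value > 10000 nM is a limit of the assay. For compound 3 the value > 10000 nM is likewise a limit. The difference between the core of compound 1 and the core of compound 2 is not broken down here.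

The change from compound 1 to compound 3 is chloro in place of hydrogen on an aromatic carbon. It gives a step that the two limits leave unreadable from compound 1 to compound 3, which rests on (the limit of > 10000 nM in this assay, at which 2 of the 3 values shown sit).

Compound 4 `CCOC(=O)/C=C/C=C/C=C/c1[nH]ccc1Cl` is not yet measured. The change from compound 2 to compound 4 is chloro in place of hydrogen on an aromatic carbon; this is the same kind of change as that from compound 1 to compound 3, the place differing only in that the neighbouring ring atom bears a large group rather than a group of 9 heavy atoms. As the earlier step is unreadable, the step from compound 2 to compound 4 is expected to be about a 1.1-fold higher number from compound 2 to compound 4 (0.04 log units; within the scatter). Compound 4 is estimated at 4000 nM, between 1200 nM and 12000 nM.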

Compound 4, half-maximal inhibitory concentration: 2420 nM
For compound 4 the middle estimate is 1.7-fold (0.22 log units) above the measured one; low and high end bracket the measured number.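

In this assay, chloro in place of hydrogen on the core of compound 2 gives a 1.5-fold lower number from compound 2 to compound 4 (0.18 log units; within the scatter), so compound 2 and compound 4 cannot be told apart in this assay. The same change on the core of compound 1 cannot be read, since compound 1 and compound 3 both stand at a limit of the assay and leave no size to set against the new step: the limit of > 10000 nM in this assay, at which 2 of the 4 values shown sit. The series therefore has one readable step on one core, which shows that the chloro change leaves the result on the core of compound 2 within the scatter, but does not show that the change behaves alike on both cores.

Going by these compounds, it remains open whether bromo, methyl or nitrile in the same place would give a step beyond the scatter. On these data alone, a carboxylic acid or an amide in place of the ethyl ester, and a longer chain on the shared core, also remain open.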